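Working notes: ether to chloro swap at the ring carbon

The source may report more compounds than this note shows. Statements on the series, on what has been measured and on what is new or still open speak of the compounds shown alone.

Measured in an assay for inhibition of kynurenine 3-monooxygenase (Homo sapiens), read by mass spectrometry, with a stated time of 1 h; on this read-out higher numbers stand for weaker inhibition and lower numbers for stronger inhibition:
compound 1, `O=C(O)CCn1c(=O)oc2cc(OCc3ccccn3)c(Cl)cc21`: 3.16 nM
compound 2, `O=C(O)CCn1c(=O)oc2cc(OCC3CC3)c(Cl)cc21`: 10 nM

Compound 2 gives the higher of the two numbers. For the measured compounds named here, the only measured step, a 3.2-fold higher number from compound 1 to compound 2 (0.50 log units; beyond the scatter), lies beyond the scatter. Compound 3, `O=C(O)CCn1c(=O)oc2cc(Cl)c(Cl)cc21`, is not yet measured. It differs from compound 2 by chloro in place of cyclopropylmethoxy on an aromatic carbon. Going by the values given here, the one measured step swapped pyridin-2-yl for cyclopropyl on a saturated chain carbon bound to an oxygen on an aromatic ring and raised the number modestly; here the whole cyclopropylmethoxy leaves and chloro enters at that aromatic carbon, a larger change that the measured step bears on only loosely. Among the compounds with values here, no measured pair shows a chloro at this place, so direction is uncertain. The expected step is a 3.0-fold higher number from compound 2 to compound 3 (0.48 log units; beyond the scatter), a further modest rise. Compound 3 is therefore expected to give 30 nM in this assay, with a range from 8 nM to 120 nM.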

Compound 3, half-maximal inhibitory concentration in the kynurenine 3-monooxygenase assay: 6.31 nM
For compound 3 the middle estimate is 4.8-fold (0.68 log units) above the measured one, outside the stated range (below it).
By their numbers in the kynurenine 3-monooxygenase assay, from the lowest: compounds 1, 3 and 2 (each within the scatter of the next, the first and the last beyond it).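

In the kynurenine 3-monooxygenase assay, replacing the whole ether with chloro gives a 1.6-fold lower number from compound 2 to compound 3 (0.20 log units; within the scatter), and a 2.0-fold higher number from compound 1 to compound 3 (0.30 log units; within the scatter), so at this aromatic carbon a lone chloro stays within the scatter of both ethers and neither ether is shown to be required. In a physicochemical assay for pharmacokinetics, at pH 6 (a higher number here means that the compound lasts longer, a lower number that the compound disappears faster), compound 2 gives > 1000 h, which is a limit of the assay: the limit of > 1000 h in the physicochemical assay, at which 1 of the 2 values shown sits. In the physicochemical assay compound 3 gives 334 h, and the same swap gives an at least 2.9-fold lower number from compound 2 to compound 3 (0.47 log units; beyond the scatter), a step beyond the scatter whose full size cannot be read.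

Going by these compounds, whether a smaller group such as fluoro, or an amine, at this aromatic carbon would keep the number in the kynurenine 3-monooxygenase assay stays open. On these data alone, it also stays open whether a longer ether chain would shift either read-out.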